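The source may report more compounds than this note shows. Statements on the series, on what has been measured and on what is new or still open speak of the compounds shown alone.

Measured in an ADME assay on L02 cells (Homo sapiens) for cytotoxicity, read by MTT assay, with a stated time of 24 h; on this read-out higher numbers stand for weaker inhibition and lower numbers for stronger inhibition:
- compound 1 `CC(=O)Nc1ccc(S(=O)(=O)N2C/C(=C\c3ccc(C#N)cc3)C(=O)/C(=C/c3ccc(C#N)cc3)C2)cc1` gives 14000 nM
- compound 2 `N#Cc1ccc(/C=C2\CN(S(=O)(=O)c3ccc(F)cc3)C/C(=C\c3ccccc3F)C2=O)cc1` gives 21900 nM
- compound 3 `COc1cc(/C=C2\CN(S(=O)(=O)c3ccc(F)cc3)C/C(=C\c3ccccc3F)C2=O)cc(OC)c1` gives 18500 nM

Compound 2 stands within the scatter of both other compounds. Compound 4 `CC(=O)Nc1ccc(S(=O)(=O)N2C/C(=C\c3ccc(C#N)cc3)C(=O)/C(=C/c3ccccc3F)C2)cc1` differs from compound 2 at one place: acetamido in place of fluoro on an aromatic carbon and, in words, acetamido in place of fluoro on an aromatic carbon. Going by the values given here, no measured step covers this change. Among the compounds with values here, the one step available, a 1.2-fold lower number from compound 2 to compound 3 (0.07 log units; within the scatter), lies at another place and shows no shift beyond the scatter. Compound 1 also carries the acetamido group, and its 14000 nM stays within the scatter of compound 2. The expected change in this assay is therefore none beyond the scatter, with an estimated 1.4-fold lower number from compound 2 to compound 4 (0.14 log units; within the scatter) as the step. For compound 4 the estimate is 16000 nM, with an expected range from 8000 nM to 32000 nM.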

Compound 4, half-maximal inhibitory concentration: 14400 nM
Estimate against measurement, compound 4: 1.1-fold (0.05 log units) above; the measured number falls inside the stated range.
By their numbers in this assay, from the lowest: compounds 1, 4, 3 and 2 (each within the scatter of the next).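

In this assay, going by these compounds alone, acetamido in place of fluoro on an aromatic carbon, para to a large group, gives the first direct reading of this change (a 1.5-fold lower number from compound 2 to compound 4 (0.18 log units; within the scatter)), and the four added heavy atoms shift the number no further than the scatter. With acetamido in place, 2-fluorophenyl in place of 4-cyanophenyl also stays within the scatter (a 1.0-fold higher number from compound 1 to compound 4 (0.01 log units; within the scatter)). Nothing at hand explains why these numbers stay so close. From the compounds shown here alone, whether an amine or a carboxylic acid at this aromatic carbon would move the number beyond the scatter remains open.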